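The source may report more compounds than this note shows. Statements on the series, on what has been measured and on what is new or still open speak of the compounds shown alone.

Measured compounds:
Compound 1, `C[C@]1(O)C[C@](c2cccc(OC(F)(F)F)c2)([C@H](O)c2ccccn2)C1`, in an ADME assay on liver for metabolic stability, with Liver microsome (Homo sapiens) as the target, read by LC-MS, using microsomes, with a stated time of 5 h (a higher number here means faster removal of the compound, a lower number slower removal), compound 1 gives 117 mL/min/kg.
Compound 2, `C[C@]1(O)C[C@](c2cccc(C(F)(F)F)c2)([C@H](O)c2ccccn2)C1`, in this assay compound 2 gives 33.3 mL/min/kg.
Compound 3, `C[C@]1(O)C[C@@](c2ccc(C(F)(F)F)cc2)([C@H](O)c2ccccn2)C1`, in this assay compound 3 gives 50 mL/min/kg.

Compound 1 and compound 2 share one core; the change between them is trifluoromethoxy in place of trifluoromethyl on an aromatic carbon, and it gave a 3.5-fold higher number from compound 2 to compound 1 (0.55 log units; beyond the scatter). Compound 3 has a different core, and the difference between the two cores is not broken down here. Compound 4, `C[C@]1(O)C[C@@](c2ccc(OC(F)(F)F)cc2)([C@H](O)c2ccccn2)C1`, has not yet been measured in this assay. It differs from compound 3 by trifluoromethoxy in place of trifluoromethyl on an aromatic carbon. For the measured compounds named here, this is the same kind of change as the one from compound 2 to compound 1, but the place is not identical: there the group sits meta to a large group, here para to a large group. Going by the values given here, since that single earlier step a 3.5-fold higher number from compound 2 to compound 1 (0.55 log units; beyond the scatter) is the only guide, a step of about a 3.0-fold higher number from compound 3 to compound 4 (0.48 log units; beyond the scatter) is expected, resting on it alone. Compound 4 is therefore estimated at 150 mL/min/kg, between 70 mL/min/kg and 320 mL/min/kg.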

Compound 4, clearance: 66.7 mL/min/kg
Estimate against measurement, compound 4: 2.2-fold (0.35 log units) above; the whole stated range lies above it.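

On the core of compound 3, trifluoromethoxy in place of trifluoromethyl gives a 1.3-fold higher number from compound 3 to compound 4 (0.13 log units; within the scatter) in this assay, so on this core the change has no clear effect. With one step beyond the scatter and the other within it, the change may or may not act differently on the two cores, and two pairs cannot fix a single size for it. The two steps cannot be told apart, which fits a change that carries over but does not prove it: the same change on two cores in this assay, a 3.5-fold higher number (0.55 log units; beyond the scatter) from compound 2 to compound 1 and a 1.3-fold higher number (0.13 log units; within the scatter) from compound 3 to compound 4, 2.6-fold (0.42 log units) apart, within the scatter of two such steps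

On these data alone, how the change behaves on any further core remains open. So does the effect of other groups at this place on the aromatic ring, such as a nitrile, a chlorine atom or an amine.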